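Shortening the chain on the triple-bonded carbon

The source may report more compounds than this note shows. Statements on the series, on what has been measured and on what is new or still open speak of the compounds shown alone.

Measured so far in a functional assay on SW-620 cells (Homo sapiens) for antiproliferative activity, read by MTT assay, with a stated time of 3 days; a lower number here means a stronger inhibitor, a higher number a weaker inhibitor:
compound 1 `CCCCCCCCC#Cc1cn(C/C=C\CN2C(=O)c3ccccc3C2=O)c(=O)[nH]c1=O` gives 67000 nM
compound 2 `CCCCCCC#Cc1cn(C/C=C/CN2C(=O)c3ccccc3C2=O)c(=O)[nH]c1=O` gives 32000 nM
compound 3 `CCCCCc1ccc(C#Cc2cn(C/C=C\CN3C(=O)c4ccccc4C3=O)c(=O)[nH]c2=O)cc1` gives > 100000 nM, which is a limit of the assay.

Compound 2 holds the lower of the two numbers; compound 1 lies beyond the scatter from it. The next compound, compound 4 `CCCCCC#Cc1cn(C/C=C/CN2C(=O)c3ccccc3C2=O)c(=O)[nH]c1=O`, carries the change (hydrogen in place of methyl on a saturated chain carbon, five bonds along the chain from a triple-bonded carbon). For the measured compounds named here, the only measured single-point step is an at least 1.4-fold higher number from compound 1 to compound 3 (0.17 log units; that floor lies within the scatter), ending at the limit (the limit of > 100000 nM in this assay, at which 1 of the 3 values shown sits), and it exchanges a chain for a ring rather than trimming a chain, so it bears only loosely here. Going by the values given here, compounds 1 and 2 differ in chain length and double-bond geometry at once, so no clean chain-length step exists. A small step from compound 2 to compound 4 is therefore expected, a 1.4-fold higher number from compound 2 to compound 4 (0.15 log units; within the scatter), direction uncertain, and compound 4 is estimated at 45000 nM (15000 nM to 130000 nM).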

Compound 4, half-maximal inhibitory concentration: 58000 nM
Beside the measured number, compound 4's estimate is 1.3-fold (0.11 log units) below it; low and high end bracket the measured number.
By their numbers in this assay, from the lowest: compounds 2, 4 and 1 (each within the scatter of the next, the first and the last beyond it). At a limit, above all of these: compound 3.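

For the compounds shown here, with the double-bond geometry held the same, this assay gives the first single-place reading of chain length: a 1.8-fold higher number from compound 2 to compound 4 (0.26 log units; within the scatter) is the whole effect of hydrogen in place of methyl at this position. Compounds 1 and 2 differ in two places at once and could not give this reading. Nothing at hand gives a cause for this step.

Going by these compounds, whether a longer chain, or an amine or a carboxylic acid in place of the chain, would move the number beyond the scatter stays open. The double-bond geometry on its own also remains unresolved.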